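A few compounds are considered here, and "the series" means these few. Any claim that something is new, unique, unknown or untested is made for them only; others in the source may bear on it.

Measured in a functional assay on HeLa cells (Homo sapiens) for antiproliferative activity, read by CCK-8 assay, with a stated time of 72 h, tested at 8 uM; on this read-out higher numbers stand for a stronger effect at the one concentration tested and lower numbers for a weaker effect:
- compound 1 `Nc1ccccc1NC(=O)c1ccc(CSC(=S)N2CCCc3ccccc32)cc1`: 35.7%
- compound 2 `Nc1ccccc1NC(=O)c1ccc(CSC(=S)N2CCN(c3ncccn3)CC2)cc1`: 73.9%
- compound 3 `Nc1ccccc1NC(=O)c1ccc(CSC(=S)N2CCN(c3cnccn3)CC2)cc1`: 76.9%

Compound 1 stands lowest of the three in this assay; compound 2 and compound 3 both sit higher by gaps that lie beyond the usual scatter of such measurements. Compound 4 `Nc1ccccc1NC(=O)c1ccc(CSC(=S)N2CCc3ccccc32)cc1` has not yet been measured. It differs from compound 1 in one place: 2,3-dihydro-1H-indol-1-yl in place of 1,2,3,4-tetrahydroquinolin-1-yl on a thiocarbonyl carbon.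

Going by the values given here, only one measured step is available, a number 3 percentage points higher from compound 2 to compound 3 (within the scatter), and it lies within the scatter. It concerns a ring on an amine nitrogen of a different part of the molecule, so it says nothing direct about swapping one fused ring system for another on the thiocarbonyl carbon. Among the compounds with values here, no measured step bears on the change from compound 1 to compound 4. With nothing to point either way, the expectation for compound 4 is a step of a number 2.3 percentage points higher from compound 1 to compound 4 (within the scatter), that is, none beyond the scatter. Compound 4 is therefore estimated at 38%, within the range 20% to 58%.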

Compound 4, a percentage reported as inhibition, at one concentration (the size of the read-out at that concentration, not a potency): 67%
Estimate against measurement, compound 4: 29 percentage points below; measured number above the stated range.
By their numbers in this assay, from the lowest: compound 1; then compounds 4, 2 and 3 (each within the scatter of the next).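

In this assay, going by these compounds alone, the group on the thiocarbonyl carbon proves highly sensitive to a small change: 2,3-dihydro-1H-indol-1-yl in place of 1,2,3,4-tetrahydroquinolin-1-yl gives a number 31.3 percentage points higher from compound 1 to compound 4 (beyond the scatter), a step that none of the earlier comparisons showed. Both groups hold a six-membered aromatic ring of carbon only, and the change lies in the non-aromatic ring, which is five-membered in the entering group and six-membered in the leaving one. Nothing available explains why this one ring change has so large an effect.

The compounds shown leave open whether a methoxy group or a fluorine atom on the aromatic ring of the 2,3-dihydro-1H-indol-1-yl group would retain this level. As far as these compounds go, it also remains open how an open-chain amine such as diethylamine would compare on the same thiocarbonyl carbon.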